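Thiophene attachment point swap in the shared core

The source may hold more compounds than are shown below. What is called first, only, known or untested is meant among the compounds shown, and "the series" means these compounds.

Compound 1 `CC(=O)C1=C(C)NC(=O)NC1c1ccsc1`, compound 2 `CCCC(=O)C1=C(C)NC(=O)NC1c1ccsc1` and compound 3 `CC1=C(C(=O)OCC2CC2)C(c2cccs2)NC(=O)N1` have been examined in an assay on membranes from HeLa cells for displacement of a labelled ligand from adenosine receptor A3 (Homo sapiens), read by scintillation counting, with a stated time of 180 min, tested at 1 uM; on this read-out higher numbers stand for more inhibition at the one concentration tested (going by the name of the read-out) and lower numbers for less inhibition. In this assay compound 1 gives 1%, compound 2 gives 1% and compound 3 gives 1%. For the measured compounds named here, the only step between two measured compounds that differ in a single place, no change at the digits printed from compound 1 to compound 2 (within the scatter), lies within the scatter. Compound 3 therefore stands level with compounds 1 and 2 at the digits shown, and the whole set sits at the low end of the read-out in this assay.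

Compound 4 `CC1=C(C(=O)OCC2CC2)C(c2ccsc2)NC(=O)N1` has not yet been measured in this assay. It differs from compound 3 as follows: thiophen-3-yl in place of thiophen-2-yl on a saturated ring carbon. Going by the values given here, no measured step covers this exact exchange. Compound 1 and compound 2 already carry a thiophen-3-yl group, compound 1 returning 1% and compound 2 returning 1% in this assay, so the attachment point of the thiophene has shown no effect beyond the scatter where it has been varied. Compound 4 is therefore expected to give 1% in this assay, with a range from 0% to 12%. The expected step of no change at the digits printed from compound 3 to compound 4 (within the scatter) is estimated to remain within the scatter.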

Compound 4, a percentage reported as inhibition, at one concentration (the size of the read-out at that concentration, not a potency): 3%
Estimate against measurement, compound 4: 2 percentage points below; the measured number falls inside the stated range.
By their numbers in this assay, from the lowest: compounds 1, 2, 3 and 4 (each within the scatter of the next).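

In this assay the swap of thiophen-2-yl for thiophen-3-yl on the saturated ring carbon now has a direct reading with cyclopropylmethoxy held constant on the carbonyl carbon (a number 2 percentage points higher from compound 3 to compound 4 (within the scatter)). With thiophen-3-yl held constant, cyclopropylmethoxy also does not separate from propyl (a number 2 percentage points higher from compound 2 to compound 4 (within the scatter)) or from methyl (a number 2 percentage points higher from compound 1 to compound 4 (within the scatter)) on that carbonyl carbon. No evidence is available that bears on why these exchanges leave the read-out flat.

From the compounds shown here alone, all four compounds sit at the low end of the read-out, so it remains open whether the thiophene attachment point matters in a compound with clear displacement. Also open, going by these compounds, is whether a phenyl group on the saturated ring carbon, or an amine or longer chain on the carbonyl carbon, would lift the read-out.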